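Notes on the shared core: ribo analogue of compound 2

The source may hold more compounds than are shown below. What is called first, only, known or untested is meant among the compounds shown, and "the series" means these compounds.

Compound 1 `CSc1nc2snc(C)c2n1[C@H]1C[C@H](O)[C@@H](CO)O1`, compound 2 `CSc1nc2sncc2n1[C@H]1C[C@H](O)[C@@H](CO)O1` and compound 3 `OC[C@H]1O[C@@H](n2c(SCc3ccccc3)nc3sncc32)C[C@@H]1O` have been run in a functional assay on L1210 cells (Mus musculus) for antiproliferative activity; a higher number here means a weaker inhibitor, a lower number a stronger inhibitor. Compound 1 gives 33000 nM, compound 2 gives 20000 nM and compound 3 gives 2200 nM. Compound 2 thus holds the second highest of the three numbers: its nearest neighbour is compound 1, with a 1.7-fold lower number from compound 1 to compound 2 (0.22 log units; within the scatter), and its furthest is compound 3, with a 9.1-fold lower number from compound 2 to compound 3 (0.96 log units; beyond the scatter). The first of these steps comes from hydrogen in place of methyl on an aromatic carbon, the second from phenyl in place of hydrogen on a saturated chain carbon bound to a sulfur. Compound 4 `CSc1nc2sncc2n1[C@@H]1O[C@H](CO)[C@@H](O)[C@H]1O` differs from compound 2 by hydroxy in place of hydrogen on a saturated ring carbon. Going by the values given here, neither measured step touches the five-membered non-aromatic ring, so no measured step bears on this change. Without a precedent in the series, no step beyond the scatter is expected in this assay, but the range is kept wide. Compound 4 is estimated at 20000 nM, between 5000 nM and 80000 nM. The expected step is no change at the digits printed from compound 2 to compound 4 (within the scatter).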

Compound 4, half-maximal inhibitory concentration: 8600 nM
Compound 4: middle estimate off by 2.3-fold (0.37 log units), on the high side; low and high end bracket the measured number.
By their numbers in this assay, from the lowest: compound 3; then compound 4; then compounds 2 and 1 (each within the scatter of the next).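

Hydroxy on this saturated ring carbon gives a 2.3-fold lower number from compound 2 to compound 4 (0.37 log units; beyond the scatter) in this assay, so the five-membered non-aromatic ring is a part of the structure where a single change can move the number beyond the scatter, though only modestly. The earlier steps shown here stayed on an aromatic carbon and on the chain bound to sulfur, and neither of them reached this ring. No measurement at hand accounts for the step.

On these data alone, the result rests on one pair, so it remains open whether the same hydroxy would give a similar step on the core of compound 3 or of compound 1. As far as these compounds go, it also remains open what an amine or a fluorine on the same ring carbon would give in place of hydroxy.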